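The source may hold more compounds than are shown below. What is called first, only, known or untested is meant among the compounds shown, and "the series" means these compounds.

Compound 1 `CCOC(=O)c1cnc2ccc(-c3cnc(OC)c(NS(=O)(=O)c4ccc(F)cc4F)c3)cn12`: 300 nM
Compound 2 `COc1ncc(-c2ccc3ncc(C(=O)O)n3c2)cc1NS(=O)(=O)c1ccc(F)cc1F`: 1150 nM

Both numbers come from a functional assay on A549 cells (Homo sapiens) for antiproliferative activity, read by sulforhodamine B assay, with a stated time of 72 h; a higher number here means a weaker inhibitor, a lower number a stronger inhibitor. Going by the values given here, compound 2 stands with the higher of the two numbers; its only neighbour is compound 1, and the step of a 3.8-fold higher number from compound 1 to compound 2 (0.58 log units; beyond the scatter) lies beyond the scatter. Compound 3 `COc1ncc(-c2ccc3ncc(C(=O)NCc4ccncc4)n3c2)cc1NS(=O)(=O)c1ccc(F)cc1F` differs from compound 2 by ((pyridin-4-yl)methyl)amino in place of hydroxy on a carbonyl carbon. Among the compounds with values here, only one measured step bears on this change, a 3.8-fold higher number from compound 1 to compound 2 (0.58 log units; beyond the scatter), in which the ethyl ester of compound 1 became the free acid of compound 2 and the number rose. Compound 3 again removes the free acid, now by an amide, so the number is expected to fall back toward that of compound 1, a step estimated at a 4.6-fold lower number from compound 2 to compound 3 (0.66 log units; beyond the scatter) in this assay. Compound 3 is therefore expected to give about 250 nM in this assay, with a likely range from 60 nM to 1000 nM.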

Compound 3, half-maximal inhibitory concentration: 500 nM
Estimate against measurement, compound 3: 2.0-fold (0.30 log units) below, and the stated range covers the measured number.
By their numbers in this assay, from the lowest: compounds 1 and 3 (each within the scatter of the next); then compound 2.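

Until now, the carbonyl carbon had carried only ethoxy and hydroxy. Replacing hydroxy with ((pyridin-4-yl)methyl)amino gives a 2.3-fold lower number from compound 2 to compound 3 (0.36 log units; beyond the scatter) in this assay and shows that an amide, like the ester, stands apart from the free acid. Against the ester, the same group gives a 1.7-fold higher number from compound 1 to compound 3 (0.22 log units; within the scatter) in this assay, so the two cannot be told apart here, even though the amide brings a six-membered aromatic ring to this place. Nothing available explains these differences.

The compounds shown leave open whether that aromatic ring contributes at all, or whether the amide alone is enough. A plain methylamino or benzylamino group on the same carbonyl carbon would separate the two, and a longer chain between the amide nitrogen and the ring would test the spacing.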